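This account rests on a few compounds, and the source may have more. Where it says the series, first, only, none or still open, it means among the compounds named here.

Measured so far in a functional assay on WM164 cells (Homo sapiens) for antiproliferative activity, read by sulforhodamine B assay, with a stated time of 48 h; on this read-out higher numbers stand for weaker inhibition and lower numbers for stronger inhibition:
- compound 1 (`CCCCCCCCCCNC(=O)[C@@H]1CSC(c2cc(OC)c(OC)c(OC)c2)N1`): 2100 nM
- compound 2 (`CCCCCCCCCCCCNC(=O)[C@@H]1CSC(c2cc(OC)c(OC)c(OC)c2)N1`): 2400 nM
- compound 3 (`CCCCCCCCCCNC(=O)[C@@H]1CSC(c2ccc(OC)c(OC)c2)N1`): 6100 nM

Compound 3, at 6100 nM, is the weakest inhibitor of the three, and its distance from each of the other two lies beyond the scatter. Compound 4 (`CCCCCCCCCCCCNC(=O)[C@@H]1CSC(c2ccc(OC)c(OC)c2)N1`) has not yet been measured. It is derived from compound 3 by a single change at the end of the chain: ethyl in place of hydrogen on a saturated chain carbon, ten or more bonds along the chain from an amide-type nitrogen.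

The same chain change has been measured once, in the series that carries the extra methoxy group, and it gave a 1.1-fold higher number from compound 1 to compound 2 (0.06 log units; within the scatter). That single pair is the direct evidence. The other measured step, a 2.9-fold higher number from compound 1 to compound 3 (0.46 log units; beyond the scatter), concerns the aromatic methoxy group rather than the chain. It matters only as a cross-check: the same aromatic change also separates compound 2 from compound 4, and applied to compound 2 at 2400 nM it points to the neighbourhood of compound 3.

Both routes agree, so no step beyond the scatter is expected in this assay. The estimate amounts to a 1.1-fold higher number from compound 3 to compound 4 (0.03 log units; within the scatter), an expected step within the scatter. Compound 4 is expected at 6500 nM, with an estimated range of 3500 nM to 12000 nM.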

Compound 4, half-maximal inhibitory concentration: 1600 nM
The estimate for compound 4 lay 4.1-fold (0.61 log units) above the measured number; the measured number lies below the stated range.
By their numbers in this assay, from the lowest: compounds 4, 1 and 2 (each within the scatter of the next); then compound 3.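

In this assay, the chain change gives a 3.8-fold lower number from compound 3 to compound 4 (0.58 log units; beyond the scatter), so ethyl in place of hydrogen at this place on the chain is not without effect on every core, and its size depends on the core that carries it: the same change on two cores in this assay, a 1.1-fold higher number (0.06 log units; within the scatter) from compound 1 to compound 2 and a 3.8-fold lower number (0.58 log units; beyond the scatter) from compound 3 to compound 4, 4.4-fold (0.64 log units) apart, beyond the scatter of two such steps

The aromatic change tells the same story from the other side, since hydrogen in place of methoxy gives a 1.5-fold lower number from compound 2 to compound 4 (0.18 log units; within the scatter), and the step seen between compound 1 and compound 3 does not recur between the compounds that carry the ethyl extension: the same change on two cores in this assay, a 2.9-fold higher number (0.46 log units; beyond the scatter) from compound 1 to compound 3 and a 1.5-fold lower number (0.18 log units; within the scatter) from compound 2 to compound 4, 4.4-fold (0.64 log units) apart, beyond the scatter of two such steps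

Taken together, the chain change and the aromatic change do not act independently of each other in these four compounds.

Going by these compounds, whether a longer chain would keep the number of compound 4 on the core of compound 3, or would move it again, remains open. On these data alone, it is equally open whether an amine or a carboxylic acid on the chain would be tolerated on either core, and whether the same dependence on the core would hold for such groups.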